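The compounds below may be only part of what the source reports. "The series", "measured", "known", "first", "only" and "open" are said of these compounds alone.

Going by the values given here, compound 1, `Cc1ccc(O)c(-c2nc(N[C@H]3CCNC3)c3ccccc3n2)c1`, is the weakest of the three compounds measured so far in an assay on isolated protein for inhibition of serine/threonine-protein kinase Chk2 (Homo sapiens) (a higher number here means a weaker inhibitor, a lower number a stronger inhibitor), where compound 1 gives 92 nM. The two others differ from it in several places at once: compound 2, `COc1cc2nc(-c3ccccc3O)nc(N[C@H]3CCNC3)c2cc1OC`, gives 28 nM in this assay, and compound 3, `COCCOc1cc2nc(-c3cc(F)ccc3O)nc(N[C@H]3CCNC3)c2cc1OC`, gives 30 nM; both numbers lie below that of compound 1 by more than the usual scatter. Among the compounds with values here, since neither differs from compound 1 in a single place, no step between measured compounds is available to guide the next change.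

Compound 4, `Oc1ccc(C(F)(F)F)cc1-c1nc(N[C@H]2CCNC2)c2ccccc2n1`, is compound 1 with one alteration: trifluoromethyl in place of methyl on an aromatic carbon. With nothing measured on this exchange, the expected step, a 1.2-fold lower number from compound 1 to compound 4 (0.09 log units; within the scatter), is small, probably no larger than the scatter, with only a slight lean toward a lower number. Compound 4 is therefore estimated at 75 nM in this assay, within a range from 30 nM to 220 nM.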

Compound 4, half-maximal inhibitory concentration: 201 nM
Beside the measured number, compound 4's estimate is 2.7-fold (0.43 log units) below it; measured number inside the range.
By their numbers in this assay, from the lowest: compounds 2 and 3 (each within the scatter of the next); then compound 1; then compound 4.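

At the place para to a hydroxy group, trifluoromethyl in place of methyl gives a 2.2-fold higher number from compound 1 to compound 4 (0.34 log units; beyond the scatter) in this assay. Going by these compounds alone, this is the first step between measured compounds that differ in one place, and it shows that the number responds to what stands at this position, with the exchange raising the number by a modest amount. Nothing measured here accounts for this step.

From the compounds shown here alone, it remains open whether chlorine, a nitrile or an amine at this position would give a number closer to that of compound 1 or to that of compound 4. Going by these compounds, it also remains open whether the same exchange would give a step of similar size and direction on the more substituted core of compound 2.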